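Compound 4: 1,3-Benzothiazol-2-yl Replaces Pyridin-2-yl on Sulfur

The source may report more compounds than this note shows. Statements on the series, on what has been measured and on what is new or still open speak of the compounds shown alone.

Compound 2 `CCOc1cc2ncnc(Nc3ccc(F)c(Cl)c3)c2cc1OC(=O)CSc1ccccn1` was measured in a functional assay on NCI-H1975 cells (Homo sapiens) for inhibition, read by MTT assay, with a stated time of 72 h (on this read-out lower numbers stand for stronger inhibition and higher numbers for weaker inhibition), where compound 2 gives 3700 nM. Among the three measured compounds it holds the second highest number. Compound 1 `C=CC(=O)Oc1cc2c(Nc3ccc(F)c(Cl)c3)ncnc2cc1OCC` gives 700 nM, and compound 3 `CCOc1cc2ncnc(Nc3ccc(F)c(Cl)c3)c2cc1OC(=O)CSc1nc2ccccc2n1C` gives 9100 nM. The steps of a 5.3-fold higher number from compound 1 to compound 2 (0.72 log units; beyond the scatter) and a 13-fold higher number from compound 1 to compound 3 (1.11 log units; beyond the scatter) are both beyond the scatter, and so is a 2.5-fold higher number from compound 2 to compound 3 (0.39 log units; beyond the scatter).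

Compound 4 `CCOc1cc2ncnc(Nc3ccc(F)c(Cl)c3)c2cc1OC(=O)CSc1nc2ccccc2s1` differs from compound 2 in one place: 1,3-benzothiazol-2-yl in place of pyridin-2-yl on a sulfur. The measured step that bears most directly on this exchange is a 2.5-fold higher number from compound 2 to compound 3 (0.39 log units; beyond the scatter), in which a 1-methyl-1H-benzimidazol-2-yl group took the place of the same pyridin-2-yl on the same sulfur and the number rose modestly. The entering 1,3-benzothiazol-2-yl group is of a closely similar kind, so a rise of comparable size is anticipated. Compound 4 is therefore expected to show a 2.0-fold higher number from compound 2 to compound 4 (0.31 log units; beyond the scatter), a modest weakening rather than a large one. Compound 4 is estimated to give 7500 nM in this assay, with a range from 3000 nM to 19000 nM.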

Compound 4, half-maximal inhibitory concentration: 9800 nM
The estimate for compound 4 lay 1.3-fold (0.12 log units) below the measured number; the measured number falls inside the stated range.
By their numbers in this assay, from the lowest: compound 1; then compound 2; then compounds 3 and 4 (each within the scatter of the next).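

In this assay, the step with a 2.6-fold higher number from compound 2 to compound 4 (0.42 log units; beyond the scatter) shows that the rise seen with 1-methyl-1H-benzimidazol-2-yl on this sulfur is not peculiar to that group, and the step with a 1.1-fold higher number from compound 3 to compound 4 (0.03 log units; within the scatter) leaves the two entering groups indistinguishable here. Replacing vinyl on the carbonyl carbon with ((1,3-benzothiazol-2-yl)sulfanyl)methyl gives a 14-fold higher number from compound 1 to compound 4 (1.15 log units; beyond the scatter) and is therefore a large change, as it was for the 1-methyl-1H-benzimidazol-2-yl counterpart. Nothing available explains why these two groups on the sulfur read alike.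

The compounds shown leave open whether a simple phenyl on the sulfur would behave like pyridin-2-yl or like the larger groups. They also leave open whether an amine or a carboxylic acid on the entering group would bring the number back towards that of compound 1.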